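The compounds below may be only part of what the source reports. "The series", "measured", "known", "first", "only" and "open" are said of these compounds alone.

Working notes on the series.

The compounds share a core carrying a propenoyl arm; compound 1 is `O=C(O)/C=C/c1ccncc1-c1ccc2cc[nH]c2c1`, compound 2 is `CCOC(=O)/C=C/c1ccncc1-c1ccc2c(ccn2C)c1`, and compound 3 is `O=C(/C=C/c1ccncc1-c1ccc2ccccc2c1)NC1CC1`. Growth inhibition is read in a functional assay on MCF7 cells (Homo sapiens) for inhibition, read by sulforhodamine B assay, with a stated time of 72 h; on this read-out higher numbers stand for weaker inhibition of growth and lower numbers for stronger inhibition of growth. In this assay compound 1 gives only > 10000 nM, which is a limit of the assay and not a number. Compound 1 therefore stands at the limit rather than on the scale, as recorded by the limit of > 10000 nM in this assay, at which 1 of the 3 values shown sits. Within the same assay compound 2 gives 8670 nM and compound 3 gives 6840 nM; these two values lie within the scatter of each other, so no order between them can be read.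

The unmeasured compound 4 is `CCOC(=O)/C=C/c1ccncc1-c1ccc2cc[nH]c2c1`. It differs from compound 1 by ethyl in place of hydrogen on an oxygen next to a carbonyl group, so the carboxy of compound 1 becomes an ethoxycarbonyl in compound 4. Compound 2 also carries the ethoxycarbonyl and gives 8670 nM, a value on the scale, which suggests that compound 4 may land in the same region. Because compound 1 reaches only a limit, the size of the step cannot be fixed from the data; the step from compound 1 to compound 4 is expected to be an at least 1.2-fold lower number from compound 1 to compound 4 (0.09 log units; that floor lies within the scatter) in this assay, towards stronger inhibition, or none beyond the scatter. For compound 4 the value in this assay is estimated at 8000 nM, with a range from 3000 nM to 30000 nM.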

Compound 4, concentration for 50% growth inhibition: 6880 nM
Beside the measured number, compound 4's estimate is 1.2-fold (0.07 log units) above it; the range from low to high includes it.
By their numbers in this assay, from the lowest: compounds 3, 4 and 2 (each within the scatter of the next). At a limit, above all of these: compound 1.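

In this assay compound 1 gives > 10000 nM, which is a limit of the assay and not a number. Carboxy to ethoxycarbonyl at this place, ethyl in place of hydrogen on an oxygen next to a carbonyl group, can now be read as a step, an at least 1.4-fold lower number from compound 1 to compound 4 (0.16 log units; that floor lies within the scatter), so that only a floor is known and this floor does not pass beyond the scatter. The earlier compounds shown here offered no pair sharing the ethoxycarbonyl on this arm, whereas compound 4 gives 6880 nM and compound 2 gives 8670 nM, two values within the scatter of each other, with no order between them.

On these data alone, the true size of the step from the carboxy to the ethoxycarbonyl cannot be read because compound 1 stands at a limit rather than on the scale: the limit of > 10000 nM in this assay, at which 1 of the 4 values shown sits. Whether the value in this assay stays in this region with a longer chain on the same oxygen, such as propyl, or with a primary amide in place of the ester on the arm of compound 4, remains open.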